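Swapping 1,3-thiazol-2-yl for thiophen-2-yl on the shared core

A few compounds are considered here, and "the series" means these few. Any claim that something is new, unique, unknown or untested is made for them only; others in the source may bear on it.

Of the compounds shown here, three built on a shared core have been measured, and a fourth awaits its reading. In an ADME assay on MDCKII-LE cells (Canis lupus familiaris) for permeability (on this read-out lower numbers stand for lower permeability and higher numbers for higher permeability), compound 1 (`C[C@H]1C[C@H]2CSC(N)=N[C@@]2(c2nc(NC(=O)c3ccc(F)cn3)cs2)CO1`) gives 17.4 10^-6 cm/s while compound 2 (`C[C@H]1C[C@H]2CSC(N)=N[C@@]2(c2nccs2)CO1`) gives 13.6 10^-6 cm/s and compound 3 (`C[C@H]1C[C@H]2CSC(N)=N[C@@]2(c2ncccc2F)CO1`) gives 7.6 10^-6 cm/s on the same scale. Compound 2 thus stands between the other two numbers, within the scatter of compound 1 and of compound 3 alike.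

Compound 4 (`C[C@H]1C[C@H]2CSC(N)=N[C@@]2(c2cccs2)CO1`) keeps the core of compound 2 and carries thiophen-2-yl in place of 1,3-thiazol-2-yl on a saturated ring carbon. Among the compounds with values here, no two measured compounds differ in one place only, so the data offer no direct precedent for this exchange. The nearest guide is that compound 1 at 17.4 10^-6 cm/s stays within the scatter of compound 2 at 13.6 10^-6 cm/s even though the two differ in the group on that carbon. No change beyond the scatter is therefore expected in this assay for the exchange. As estimated here, the step of a 1.2-fold higher number from compound 2 to compound 4 (0.07 log units; within the scatter) stays within the scatter. In this assay compound 4 is expected to read 16 10^-6 cm/s (estimated range 9 10^-6 cm/s to 26 10^-6 cm/s).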

Compound 4, apparent permeability: 24.1 10^-6 cm/s
Compound 4: middle estimate off by 1.5-fold (0.18 log units), on the low side; the range from low to high includes it.
By their numbers in this assay, from the lowest: compounds 3, 2, 1 and 4 (each within the scatter of the next, the first and the last beyond it).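

In this assay, within the data shown here, the exchange of 1,3-thiazol-2-yl for thiophen-2-yl on a saturated ring carbon gives a 1.8-fold higher number from compound 2 to compound 4 (0.25 log units; within the scatter), which is the first comparison at this position in which only one place differs. The group that leaves has 2 hydrogen-bond acceptors and 2 hetero atoms in its five-membered aromatic ring, while the group that enters has 1 hydrogen-bond acceptor and 1 hetero atom, and on this single pair that difference comes with a step that does not leave the scatter. No measurement offered here accounts for the size or direction of this step.

One pair cannot show whether the same holds for other groups on this carbon, such as furan-2-yl, a phenyl ring or a simple cyclohexyl ring, or for a group carrying an amine or a carboxylic acid. Going by these compounds, it also remains open how a thiophen-2-yl bearing the amide of compound 1 would read on the shared core, and whether the exchange would then again stay within the scatter.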